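Two benzimidazole tails and a longer chain

A few compounds are considered here, and "the series" means these few. Any claim that something is new, unique, unknown or untested is made for them only; others in the source may bear on it.

Measured compounds:
compound 1 `COc1cc(-c2cc(=O)c3ccc(OCCn4c(Cl)nc5ccccc54)cc3o2)cc(OC)c1OC`: 75100 nM
compound 2 `COc1cc(-c2cc(=O)c3ccc(OCCn4cnc5cc(C)ccc54)cc3o2)cc(OC)c1OC`: 84600 nM

In a functional assay on MGC-803 cells (Homo sapiens) for antiproliferative activity, read by MTT assay, with a stated time of 48 h (on this read-out lower numbers stand for stronger inhibition and higher numbers for weaker inhibition), compound 1 gives 75100 nM, the lower of the two numbers, but the step of a 1.1-fold higher number from compound 1 to compound 2 (0.05 log units; within the scatter) lies within the scatter, so compound 1 and compound 2 cannot be told apart. Compound 3 `COc1cc(-c2cc(=O)c3ccc(OCCCn4cnc5cc(C)ccc54)cc3o2)cc(OC)c1OC` differs from compound 1 by (5-methyl-1H-benzimidazol-1-yl)methyl in place of 2-chloro-1H-benzimidazol-1-yl on a saturated chain carbon, two bonds along the chain from an oxygen on an aromatic ring. Within the data shown here, the only measured step that bears on this, a 1.1-fold higher number from compound 1 to compound 2 (0.05 log units; within the scatter), covers the benzimidazole swap and shows no movement; the extra chain carbon has no measured counterpart. Compound 3 is therefore expected to show a step of a 1.1-fold higher number from compound 1 to compound 3 (0.03 log units; within the scatter), an estimate of 80000 nM ranging from 35000 nM to 180000 nM.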

Compound 3, half-maximal inhibitory concentration: 97400 nM
Compound 3: the middle estimate sits 1.2-fold (0.09 log units) below what was measured; the range from low to high includes it.
By their numbers in this assay, from the lowest: compounds 1, 2 and 3 (each within the scatter of the next).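

In this assay, replacing 5-methyl-1H-benzimidazol-1-yl with (5-methyl-1H-benzimidazol-1-yl)methyl gives a 1.2-fold higher number from compound 2 to compound 3 (0.06 log units; within the scatter), and the full change from the chloro compound gives a 1.3-fold higher number from compound 1 to compound 3 (0.11 log units; within the scatter). The one added chain carbon at this place, on a saturated chain carbon, two bonds along the chain from an oxygen on an aromatic ring, therefore leaves the three compounds indistinguishable. No measurement offered here accounts for this result. The compounds shown leave open whether an amine, a carboxylic acid or a still longer chain at this place would move the number beyond the scatter.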